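Urea aryl swap: trifluoromethyl for chloro in compound 1

This account rests on a few compounds, and the source may have more. Where it says the series, first, only, none or still open, it means among the compounds named here.

Compound 1 `COc1cc(-c2nn(-c3cccc(NC(=O)Nc4ccc(Cl)c(Cl)c4)c3)cc2-c2ccncc2)ccc1Cl` is, in a functional assay on OVCAR-4 cells (Homo sapiens) for inhibition, read by sulforhodamine B assay, with a stated time of 48 h (a higher number here means a weaker inhibitor of growth, a lower number a stronger inhibitor of growth), at 1290 nM, the second highest of the three numbers measured. Its nearest neighbour is compound 2 `O=C(Nc1cccc(-n2cc(-c3ccncc3)c(-c3ccc(Cl)c(O)c3)n2)c1)Nc1ccc(Cl)c(Cl)c1` at 1690 nM; the step of a 1.3-fold higher number from compound 1 to compound 2 (0.12 log units; within the scatter) lies within the scatter. Furthest is compound 3 `O=C(Nc1cccc(-n2cc(-c3ccncc3)c(-c3ccc(Cl)c(O)c3)n2)c1)Nc1cc(C(F)(F)F)cc(C(F)(F)F)c1` at 849 nM, also within the scatter of compound 1.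

Compound 4 `COc1cc(-c2nn(-c3cccc(NC(=O)Nc4ccc(Cl)c(C(F)(F)F)c4)c3)cc2-c2ccncc2)ccc1Cl` differs from compound 1 by trifluoromethyl in place of chloro on an aromatic carbon. Among the measured compounds shown here, no measured step covers exactly this change; the closest comparison is compound 2 against compound 3, where both substituents of the distal ring are exchanged, and those two values sit roughly within the scatter of each other. The step of a 1.3-fold lower number from compound 1 to compound 4 (0.11 log units; within the scatter) is therefore expected to be small, with no clear direction. Compound 4 is estimated at 1000 nM, range 400 nM to 2500 nM.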

Compound 4, concentration for 50% growth inhibition: 1290 nM
For compound 4 the middle estimate is 1.3-fold (0.11 log units) below the measured one, within the range that was stated.
By their numbers in this assay, from the lowest: compounds 3, 1, 4 and 2 (each within the scatter of the next).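

In this assay the swap on the urea aryl ring reads no change at the digits printed from compound 1 to compound 4 (within the scatter). Among the compounds shown here, this gives the first single-place reading at this ring: on this aromatic carbon, ortho to a chloro group, trifluoromethyl replaces chloro, adding three heavy atoms, with no shift beyond the scatter. No available evidence bears on the reason for this result. Still open, from the compounds shown here alone, is whether an amine or a carboxylic acid on the same carbon would also leave the number within the scatter. Also open, going by these compounds, is how the 4-chloro group itself contributes.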